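Amino for a sulfonyl group on a shared core

The source may hold more compounds than are shown below. What is called first, only, known or untested is meant among the compounds shown, and "the series" means these compounds.

compound 1 `O=S(=O)(NCC1COC1)c1cccc(-c2ccc3nccc(-c4ccncc4)c3n2)c1`: 8%
compound 2 `O=S(=O)(c1cccc(-c2ccc3nccc(-c4ccncc4)c3n2)c1)N1CCC(O)CC1`: 11%
compound 3 `O=S(=O)(c1cccc(-c2ccc3nccc(-c4ccncc4)c3n2)c1)N1CC[C@H](O)C1`: 10%

All three values come from an ADME assay on microsomes from liver (Rattus norvegicus) for metabolic stability, read by LC-MS, using NADPH, with a stated time of 30 min, tested at 0.1 uM; on this read-out lower numbers stand for a less stable compound and higher numbers for a more stable compound. Compound 3 cannot be ranked against the other two, since the measured changes are a number 1 percentage points lower from compound 2 to compound 3 (within the scatter) and a number 2 percentage points higher from compound 1 to compound 3 (within the scatter). Compound 4 `Nc1cccc(-c2ccc3nccc(-c4ccncc4)c3n2)c1` has amino in place of (3-hydroxypyrrolidin-1-yl)sulfonyl on an aromatic carbon. The measured steps, which also include a number 3 percentage points higher from compound 1 to compound 2 (within the scatter), only exchange the group on the sulfonyl sulfur. None removes the sulfonyl group, so they guide this change only weakly. No shift beyond the scatter is expected in either direction, and the expected change is a number 1 percentage points higher from compound 3 to compound 4 (within the scatter). For compound 4 the estimated value is 11%, with an expected range from 3% to 30%.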

Compound 4, percent of the compound remaining: 61%
Beside the measured number, compound 4's estimate is 50 percentage points below it; the whole stated range lies below it.
By their numbers in this assay, from the lowest: compounds 1, 3 and 2 (each within the scatter of the next); then compound 4.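

In this assay, swapping the group on the sulfonyl sulfur moved the number only within the scatter, but replacing the whole sulfonyl unit with amino gives a large rise (a number 51 percentage points higher from compound 3 to compound 4 (beyond the scatter); a number 50 percentage points higher from compound 2 to compound 4 (beyond the scatter); a number 53 percentage points higher from compound 1 to compound 4 (beyond the scatter)). At this aromatic carbon, then, the outcome depends far more on whether the sulfonyl unit is present than on what it carries. Nothing available explains this rise.

As far as these compounds go, whether the rise comes from the amino group itself or simply from losing the sulfonyl stays open. A bare hydrogen, a methylamino group or an acetamide on this aromatic carbon would help separate the two.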